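A Fluorinated Side Chain Rearranged: Compound 4 Awaits Measurement

A few compounds are considered here, and "the series" means these few. Any claim that something is new, unique, unknown or untested is made for them only; others in the source may bear on it.

In an ADME assay for permeability, using PAMPA, with a stated time of 4 h, at pH 7.4 (on this read-out higher numbers stand for higher permeability and lower numbers for lower permeability), compound 1 (`C/C(CN)=C(/F)CN(C[C@H]1Cc2ccccc2CN1)[C@H]1CCCc2cccnc21`) gives 220 nm/s, the second highest of three numbers. Compound 2 (`C/C(=C/CN(C[C@H]1Cc2ccccc2CN1)[C@H]1CCCc2cccnc21)CN`) gives 11 nm/s, and compound 3 (`C/C(CN(C[C@H]1Cc2ccccc2CN1)[C@H]1CCCc2cccnc21)=C(/F)CN`) gives 700 nm/s. Compound 4 (`C/C(CN(C[C@H]1Cc2ccccc2CN1)[C@H]1CCCc2cccnc21)=C(\F)CN`) has not yet been measured. Its difference from compound 1 is 3-amino-2-fluoro-1-methylprop-1-en-1-yl in place of 2-(aminomethyl)-1-fluoroprop-1-en-1-yl on a saturated chain carbon bound to an amine nitrogen.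

The closest evidence is a 3.2-fold higher number from compound 1 to compound 3 (0.50 log units; beyond the scatter), a modest step that carries the same replacement by name. The two large steps, a 20-fold lower number from compound 1 to compound 2 (1.30 log units; beyond the scatter) and a 64-fold higher number from compound 2 to compound 3 (1.80 log units; beyond the scatter), exchange a group containing fluorine for one without it or the reverse, and compound 4 makes no such exchange. They therefore bear on it less directly.

A modest rise is expected in this assay, although the data hold no direct measurement of this exact group. The expected change is a 2.3-fold higher number from compound 1 to compound 4 (0.36 log units; beyond the scatter). Compound 4 is estimated at 500 nm/s, with an expected range of 180 nm/s to 1300 nm/s.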

Compound 4, apparent permeability: 550 nm/s
The estimate for compound 4 lay 1.1-fold (0.04 log units) below the measured number; the measured number falls inside the stated range.
By their numbers in this assay, from the lowest: compound 2; then compound 1; then compounds 4 and 3 (each within the scatter of the next).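

In this assay, both double-bond forms of the 3-amino-2-fluoro-1-methylprop-1-en-1-yl group are now on record, and they cannot be told apart, with a 1.3-fold lower number from compound 3 to compound 4 (0.10 log units; within the scatter). The rise over the 2-(aminomethyl)-1-fluoroprop-1-en-1-yl group therefore does not rest on one drawn geometry, as shown by a 2.5-fold higher number from compound 1 to compound 4 (0.40 log units; beyond the scatter), while the gap to the chain without fluorine stays large, at a 50-fold higher number from compound 2 to compound 4 (1.70 log units; beyond the scatter). This pair isolates double-bond geometry as the single point of change: the fact that compounds 3 and 4 differ only in the configuration as drawn

The only chain without fluorine shown has the arrangement of compound 1, so the weight of fluorine in the arrangement of compound 4 remains open. Also open, from the compounds shown here alone, is how this position would respond to a chlorine atom in place of the fluorine or a dimethylamino group in place of the amino group.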